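The source may hold more compounds than are shown below. What is called first, only, known or untested is meant among the compounds shown, and "the series" means these compounds.

Measured compounds and values:
compound 1 `COc1ccc([C@@H]2OC[C@H]([C@@H](O)c3ccc(OC)c(OC)c3)C[C@H]2C/C=C/c2ccc(OC)c(OC)c2)cc1` — 29200 nM in a functional assay on HeLa cells (Homo sapiens) for cytotoxicity, read by WST assay, with a stated time of 48 h; a higher number here means a weaker inhibitor, a lower number a stronger inhibitor;
compound 2 `COc1ccc([C@H]2OC[C@H]([C@@H](O)c3ccc(OC)c(OC)c3)C[C@@H]2C/C=C/c2ccc(OC)c(OC)c2)cc1` — 46700 nM;
compound 3 `Oc1cccc(/C=C/C[C@H]2C[C@@H]([C@@H](O)c3ccccc3)CO[C@@H]2c2ccccc2)c1` — 18600 nM.

Compound 1 stands second highest of these three numbers, yet both its neighbours lie within the scatter of it, so no order among them can be read. Compound 4 `COc1ccc(/C=C/C[C@@H]2C[C@@H]([C@@H](O)c3ccc(OC)c(OC)c3)CO[C@H]2c2ccc(OC)c(OC)c2)cc1OC` differs from compound 1 by methoxy in place of hydrogen on an aromatic carbon, the new group sitting on a six-membered aromatic ring of carbon only, ortho to a methoxy group. Among the measured compounds shown here, the single measured step, a 1.6-fold higher number from compound 1 to compound 2 (0.20 log units; within the scatter), concerns configuration alone, as seen in the fact that compounds 1 and 2 differ only in the configuration as drawn; no measured step exchanges a hydrogen for a methoxy, so it offers no guide here. The step of a 1.1-fold lower number from compound 1 to compound 4 (0.03 log units; within the scatter) is therefore expected to stay within the scatter. Compound 4 is estimated at 27000 nM, between 9000 nM and 80000 nM.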

Compound 4, half-maximal inhibitory concentration: 30600 nM
The estimate for compound 4 lay 1.1-fold (0.05 log units) below the measured number; the range from low to high includes it.
By their numbers in this assay, from the lowest: compounds 3, 1, 4 and 2 (each within the scatter of the next, the first and the last beyond it).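

Replacing 4-methoxyphenyl with 3,4-dimethoxyphenyl gives a 1.0-fold higher number from compound 1 to compound 4 (0.02 log units; within the scatter) in this assay, so compound 1 and compound 4 cannot be told apart. Among the compounds shown here, this is the first measured step that alters a substituent rather than configuration, and it shows that a methoxy on this aromatic carbon, ortho to a methoxy group, costs nothing readable here. Nothing measured here bears on the reason for this result.

On these data alone, whether an amine, a carboxylic acid or a longer chain such as ethoxy at this position would shift the number remains open. So does whether the added methoxy would read the same with the configuration of compound 2.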